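Adding a chloro to the most potent chain compound

A few compounds are considered here, and "the series" means these few. Any claim that something is new, unique, unknown or untested is made for them only; others in the source may bear on it.

In a functional assay on A549 cells (Homo sapiens) for inhibition, read by colorimetric assay and MTT assay, with a stated time of 72 h (a lower number here means a stronger inhibitor, a higher number a weaker inhibitor), the measured compounds stand as follows:

Compound 1 `CCCCCCOc1ncc(-c2ccccc2OC)n1C` gives 37000 nM
Compound 2 `C#CCCCCOc1ncc(-c2ccccc2OC)n1C` gives 22000 nM
Compound 3 `C=CCCCCOc1ncc(-c2ccccc2OC)n1C` gives 5000 nM

Compound 3 has the lowest number of the three, and its gaps to both others lie beyond the scatter. The next compound, compound 4 `C=CCCCCOc1ncc(-c2ccc(Cl)cc2OC)n1C`, keeps the chain of compound 3. The change chloro in place of hydrogen on an aromatic carbon is a chloro in place of hydrogen on an aromatic carbon, meta to a methoxy group and para to a large group.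

The measured steps offer only indirect help. They are a 1.7-fold lower number from compound 1 to compound 2 (0.23 log units; within the scatter) and a 7.4-fold lower number from compound 1 to compound 3 (0.87 log units; beyond the scatter) and also a 4.4-fold lower number from compound 2 to compound 3 (0.64 log units; beyond the scatter) and all of them alter the chain. Going by the values given here, none touches the aromatic ring, so nothing measured so far speaks directly to a chloro there. A small move toward a lower number is the working expectation, though not one clearly beyond the scatter. The expected change is a 1.4-fold lower number from compound 3 to compound 4 (0.15 log units; within the scatter) and it remains an estimate. The uncertainty is kept about as wide as the largest chain step, a 7.4-fold lower number from compound 1 to compound 3 (0.87 log units; beyond the scatter) in either direction. For compound 4 the estimated value is 3500 nM with 1200 nM to 10000 nM as the expected range.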

Compound 4, half-maximal inhibitory concentration: 47000 nM
Compound 4: the middle estimate sits 13-fold (1.13 log units) below what was measured; measured number above the stated range.
By their numbers in this assay, from the lowest: compound 3; then compounds 2, 1 and 4 (each within the scatter of the next, the first and the last beyond it).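

In this assay, putting a chloro in place of hydrogen on the aromatic carbon that is meta to a methoxy group and para to a large group gives (a 9.4-fold higher number from compound 3 to compound 4 (0.97 log units; beyond the scatter)), a step beyond the scatter and toward a weaker inhibitor. Going by these compounds alone, all the earlier steps altered the chain, so this is the first sign in these compounds that the aromatic ring also affects the number, and that one added chlorine atom on it can outweigh the benefit seen with the chain of compound 3. Nothing measured here explains why this single atom has such an effect on the cell result.

The compounds shown leave open whether the rise is specific to chloro or would also follow from another group on the same carbon, such as a fluoro, a methyl or an amine. On these data alone, it also remains open whether a chloro at another position on this ring would behave in the same way, and whether the same change would give a step of similar size on compound 1 or compound 2, with their different chains.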